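Working notes: an aryl exchange on compound 2

This account rests on a few compounds, and the source may have more. Where it says the series, first, only, none or still open, it means among the compounds named here.

Measured in a functional assay on PC-3 cells (Homo sapiens) for cytotoxicity, read by MTT assay, with a stated time of 48 h; on this read-out lower numbers stand for stronger inhibition and higher numbers for weaker inhibition:
- compound 1 `COc1ccc(-c2c[nH]c(=O)n2-c2cc(OC)c(OC)c(OC)c2)cc1OC`: > 50000 nM
- compound 2 `COc1cc(NC(=O)n2cc(-c3ccc(O)cc3)n(-c3cc(OC)c(OC)c(OC)c3)c2=O)cc(OC)c1OC`: 3000 nM

The entry for compound 1, > 50000 nM, is a limit of the assay and not a number. For the measured compounds named here, compound 2, at 3000 nM, therefore holds the only true number so far.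

Compound 3 `COc1ccc(-c2cn(C(=O)Nc3cc(OC)c(OC)c(OC)c3)c(=O)n2-c2cc(OC)c(OC)c(OC)c2)cc1OC` is to be measured next. It departs from compound 2 in one place, with 3,4-dimethoxyphenyl in place of 4-hydroxyphenyl on an aromatic carbon. Going by the values given here, compound 1 also carries 3,4-dimethoxyphenyl, but its core is otherwise not that of compound 2, and no measured step isolates this exchange. A modest move towards weaker inhibition is expected, as a 2.0-fold higher number from compound 2 to compound 3 (0.30 log units; within the scatter), and this size is only an estimate. Compound 3 is estimated at 6000 nM, with an expected range of 1500 nM to 25000 nM.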

Compound 3, half-maximal inhibitory concentration: > 50000 nM
Compound 3 gave a limit, no number; the forecaster's own chance of this, stated with the estimate: 15%; middle value at least 8.3-fold (0.92 log units) from the limit.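

In this assay, for the compounds shown here, 3,4-dimethoxyphenyl in place of 4-hydroxyphenyl gives an at least 16-fold higher number from compound 2 to compound 3 (1.22 log units; beyond the scatter), the first step that isolates a change on this aromatic carbon. Compound 3 gives > 50000 nM, which is a limit of the assay and not a number. The position is therefore sensitive to the aryl group it carries, since this one exchange is enough to lose the measurable value of compound 2, but the full size of the step stays unresolved because the reading ends at the assay limit: the limit of > 50000 nM in this assay, at which 2 of the 3 values shown sit.

The exchange removes the 4-hydroxy group and adds two methoxy groups at once, so the compounds shown do not separate these changes. Going by these compounds, how 4-methoxyphenyl or 4-aminophenyl on this carbon would read also remains open.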